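Moving the methyl group from compound 3 to compound 4

A few compounds are considered here, and "the series" means these few. Any claim that something is new, unique, unknown or untested is made for them only; others in the source may bear on it.

In a functional assay on a cell-free system (Platelet, plasma, Oryctolagus cuniculus) for inhibition, with stated times of 5 min and 6 min (on this read-out lower numbers stand for stronger inhibition and higher numbers for weaker inhibition), compound 1 `CCCN1C(=O)COc2cc(CNc3ccccc3)ccc21` gives 10100 nM. Compound 2 `CCCN1C(=O)COc2cc(CNc3ccccc3C)ccc21` gives 18800 nM. Compound 3 `CCCN1C(=O)COc2cc(CNc3cccc(C)c3)ccc21` gives 13900 nM. Compound 3 stands within the scatter of both other compounds, and the three values show no measurable separation.

Compound 4 `CCCN1C(=O)COc2cc(CNc3ccc(C)cc3)ccc21` has the same atoms as compound 3, joined differently, with 4-methylphenyl in place of 3-methylphenyl on an amine nitrogen. Going by the values given here, no measured compound yet carries 4-methylphenyl, so the expectation rests on neighbouring changes. Among the compounds with values here, the nearest precedent swaps one methylphenyl for another, and it gives a 1.4-fold lower number from compound 2 to compound 3 (0.13 log units; within the scatter). Methyl in place of hydrogen on an aromatic carbon gives a 1.9-fold higher number from compound 1 to compound 2 (0.27 log units; within the scatter) and a 1.4-fold higher number from compound 1 to compound 3 (0.14 log units; within the scatter). All three steps remain within the scatter, so no step beyond the scatter is expected in this assay, and no direction can be assigned.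

The expected step is a 1.0-fold higher number from compound 3 to compound 4 (0.00 log units; within the scatter). Compound 4 is estimated at 14000 nM, with an expected range of 7000 nM to 28000 nM.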

Compound 4, half-maximal inhibitory concentration: 14200 nM
For compound 4 the middle estimate is 1.0-fold (0.01 log units) below the measured one, and the stated range covers the measured number.
By their numbers in this assay, from the lowest: compounds 1, 3, 4 and 2 (each within the scatter of the next).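

Read in this assay the 4-methylphenyl group on the amine nitrogen completes a comparison of methyl placements on this phenyl: the step from the 3-methylphenyl group is small (a 1.0-fold higher number from compound 3 to compound 4 (0.01 log units; within the scatter)), the step from the 2-methylphenyl group is similar in size (a 1.3-fold lower number from compound 2 to compound 4 (0.12 log units; within the scatter)), and the step from the unsubstituted phenyl group also stays small (a 1.4-fold higher number from compound 1 to compound 4 (0.15 log units; within the scatter)). Every step among the four compounds lies within the scatter, so in this set neither adding the methyl nor changing its placement on the phenyl separates the values, and compound 1 and compound 4 join compound 2 and compound 3 in one unresolved group. No measured information available here accounts for this flat result.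

Methyl is the only substituent shown on this phenyl, so it remains open whether methoxy, chlorine, trifluoromethyl or a carboxylic acid at the same places would give a step beyond the scatter. Also open, as far as these compounds go, is whether replacing the propyl chain of the shared core with a longer chain would move the values.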